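The source may report more compounds than this note shows. Statements on the series, on what has been measured and on what is new or still open speak of the compounds shown alone.

Measured so far:
compound 1 `C=CCOCC(N)C(=O)NCc1ccccc1` — 45 mg/kg
compound 2 `CCCC[C@@H](N)C(=O)NCc1ccccc1` — 23 mg/kg
compound 3 `CSCC[C@@H](N)C(=O)NCc1ccccc1` — 75 mg/kg

In a functional assay on the whole organism (strain NMRI) with Mus musculus as the target, in the maximal electroshock model, with a stated time of 30 min (a higher number here means that more compound is needed for the effect, a lower number that less compound is needed), compound 1 stands second highest of the three numbers; its gaps to compound 2 and to compound 3 both lie within the scatter. Within the data shown here, the only step between measured compounds is a 3.3-fold higher number from compound 2 to compound 3 (0.51 log units; beyond the scatter), a swap at a different place on the chain and with different groups, so it bears only loosely on the present change.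

Compound 4 `CN(C)CC(N)C(=O)NCc1ccccc1` differs from compound 1 by dimethylamino in place of allyloxy on a saturated chain carbon, two bonds along the chain from an amine nitrogen and a carbonyl carbon. Among the measured compounds shown here, no measured pair covers this exchange; the series offers no guidance. The step from compound 1 to compound 4 is therefore expected to be a 1.1-fold higher number from compound 1 to compound 4 (0.05 log units; within the scatter), that is, none beyond the scatter. For compound 4 in this assay the expected value is 50 mg/kg, with a range from 20 mg/kg to 130 mg/kg.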

Compound 4, dose for half-maximal effect: 94 mg/kg
For compound 4 the middle estimate is 1.9-fold (0.27 log units) below the measured one; the measured number falls inside the stated range.
By their numbers in this assay, from the lowest: compounds 2, 1, 3 and 4 (each within the scatter of the next, the first and the last beyond it).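

In this assay, dimethylamino in place of allyloxy on this saturated chain carbon gives a 2.1-fold higher number from compound 1 to compound 4 (0.32 log units; beyond the scatter) and thus shows that the number responds to the group at this place, though only modestly. This is the only step at this position among the compounds shown, so it gives a single exchange and no trend across groups. Nothing available accounts for the step.

As far as these compounds go, whether a methoxy group or a longer ether chain at this place would stay near compound 1 remains open. So does whether a cyclic amine such as morpholine would stay near compound 4.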